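Cytotoxicity series: removing trifluoromethyl from the benzamide

The source may report more compounds than this note shows. Statements on the series, on what has been measured and on what is new or still open speak of the compounds shown alone.

Measured so far in a functional assay on 786-0 cells (Homo sapiens) for inhibition, read by sulforhodamine B assay, with a stated time of 48 h; on this read-out higher numbers stand for lower toxicity in this test and lower numbers for higher toxicity in this test:
Compound 1 `COc1cc(-c2nn(-c3cccc(NC(=O)c4cccc(C(F)(F)F)c4)c3)cc2-c2ccncc2)ccc1Cl` gives > 50000 nM, which is a limit of the test and not a number.
Compound 2 `COc1cc(-c2nn(-c3cccc(NC(=O)Nc4cccc(C(F)(F)F)c4)c3)cc2-c2ccncc2)ccc1Cl` gives > 50000 nM, again a limit of the test.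
Compound 3 `O=C(Nc1cccc(-n2cc(-c3ccncc3)c(-c3ccc(Cl)c(O)c3)n2)c1)Nc1cc(C(F)(F)F)cc(C(F)(F)F)c1` gives 18000 nM.

Compound 1 therefore stands only at the upper limit of this assay; no number is known for it. Going by the values given here, compound 2 sits at the same limit, so the step from compound 1 to compound 2 reads as a step that the two limits leave unreadable from compound 1 to compound 2; this is the only measured step, and it bears on nothing beyond the fact that both compounds rest at the limit of > 50000 nM in this assay, at which 2 of the 3 values shown sit. Among the compounds with values here, compound 3 is the one compound with a number; no single-point step connects it to compound 1, so all that can be said is that compound 3 gives a value where compound 1 gives a limit.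

Compound 4 `COc1cc(-c2nn(-c3cccc(NC(=O)c4ccccc4)c3)cc2-c2ccncc2)ccc1Cl` differs from compound 1 by hydrogen in place of trifluoromethyl on an aromatic carbon. Within the data shown here, no measured step removes a trifluoromethyl, and the one step leaving compound 1 is unreadable. The step that the limit leaves unreadable from compound 1 to compound 4 is expected to be small and most likely unreadable. Compound 4 is expected at about 60000 nM, within 20000 nM to 200000 nM, and most probably again reported as a limit.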

Compound 4, concentration lethal to 50% of the cells: > 100000 nM
Compound 4: a limit, no number (the forecaster's own chance of this, stated with the estimate: 75%); at least 1.6-fold (0.22 log units) between middle value and limit.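

In this assay compound 4 gives > 100000 nM, a limit of the test and not a number. Compound 1 and compound 2 also rest at limits, so neither step to compound 4 can be read. The compounds shown leave open whether hydrogen in place of trifluoromethyl changes the toxicity of compound 1 at all in this assay.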